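Swapping Hydroxy for Nitro on the Aromatic Ring

The source may report more compounds than this note shows. Statements on the series, on what has been measured and on what is new or still open speak of the compounds shown alone.

Within the data shown here, in a functional assay on K562 cells (Homo sapiens) for cytotoxicity, read by sulforhodamine B assay (on this read-out lower numbers stand for stronger inhibition of growth and higher numbers for weaker inhibition of growth), compound 2 (`CC1=CC[C@@H]([C@@](C)(O)CCCC(C)(C)NC(=S)N/N=C\c2ccc(O)cc2)CC1`) gives 600 nM as the higher of the two numbers measured so far. The lower number comes from compound 1 (`CC1=CC[C@@H]([C@@](C)(O)CCCC(C)(C)NC(=S)NN)CC1`), which gives 20 nM in the same test.

Compound 3 (`CC1=CC[C@@H]([C@@](C)(O)CCCC(C)(C)NC(=S)N/N=C\c2ccc([N+](=O)[O-])cc2)CC1`) carries nitro in place of hydroxy on an aromatic carbon and is otherwise the same as compound 2.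

Among the measured compounds shown here, only one measured step bears on this, and only indirectly. Attaching the whole aromatic group gave a large change (a 30-fold higher number from compound 1 to compound 2 (1.48 log units; beyond the scatter)) but no measured pair yet varies a group on that ring. Both compound 2 and compound 3 keep the ring, so no clear shift is expected in this assay, and neither direction is favoured. The expected step is a 1.2-fold lower number from compound 2 to compound 3 (0.08 log units; within the scatter) and it may well stay within the scatter. The estimated value for compound 3 is 500 nM with an expected range from 150 nM to 1800 nM in this test.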

Compound 3, concentration for 50% growth inhibition: 4220 nM
For compound 3 the middle estimate is 8.4-fold (0.93 log units) below the measured one; measured number above the stated range.
By their numbers in this assay, from the lowest: compound 1; then compound 2; then compound 3.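

In this assay the group on the aromatic ring matters, since nitro in place of hydroxy gives a 7.0-fold higher number from compound 2 to compound 3 (0.85 log units; beyond the scatter) with the rest of the molecule unchanged. The earlier step showed only what attaching the whole aromatic group does, whereas this one shows that the change from 4-hydroxyphenyl to 4-nitrophenyl can move the number by itself, beyond the scatter. Nothing available here gives a measured reason for this shift.

Among these compounds, with only two groups seen at this ring carbon, it remains open whether the higher number goes with losing hydroxy or with gaining nitro, and an amine, a methoxy group or a plain hydrogen there would help separate the two. Also open, going by these compounds, is whether any group on this ring can bring the number close to that of compound 1 at 20 nM in this test.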